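Adding a second chloro to the core of compound 2

The source may hold more compounds than are shown below. What is called first, only, known or untested is meant among the compounds shown, and "the series" means these compounds.

Compound 2 `ClCc1cccc(Cn2cnc3ncnc(Cl)c32)c1` and compound 1 `ClCc1ccccc1Cn1cnc2c(Cl)ncnc21` share a core and differ in where the chloromethylbenzyl arm sits. In a functional assay on NCI-H226 cells (Homo sapiens) for cytotoxicity, read by sulforhodamine B assay, with a stated time of 48 h (a higher number here means a weaker inhibitor of growth, a lower number a stronger inhibitor of growth), compound 2 gives 8700 nM, the lower of the two numbers, while compound 1 gives 12600 nM; the gap between them is within the usual scatter. Compound 3 `ClCc1cccc(Cn2cnc3nc(Cl)nc(Cl)c32)c1` has not yet been measured; it differs from compound 2 by chloro in place of hydrogen on an aromatic carbon. Among the measured compounds shown here, no comparable step is known here, so the expected step of a 1.2-fold lower number from compound 2 to compound 3 (0.09 log units; within the scatter) is small, with no clear direction beyond the scatter. The estimate for compound 3 is 7000 nM, with a range from 2500 nM to 20000 nM.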

Compound 3, concentration for total growth inhibition: 3630 nM
Compound 3: middle estimate off by 1.9-fold (0.29 log units), on the high side, within the range that was stated.
By their numbers in this assay, from the lowest: compound 3; then compounds 2 and 1 (each within the scatter of the next).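

In this assay, chloro in place of hydrogen on the aromatic carbon between two ring nitrogen atoms gives a 2.4-fold lower number from compound 2 to compound 3 (0.38 log units; beyond the scatter), a modest step but one beyond the scatter. The number therefore responds to what sits at this position of the core, whereas the gap between compound 1 and compound 2, which differ in where the arm sits, stays within the scatter. Nothing measured here gives a reason for this step.

Going by these compounds, whether an amine or a methoxy group at this carbon would shift the number, and in which direction, remains open. Also open, on these data alone, is whether the chloro step would carry over to the arm placement of compound 1.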